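Cytotoxicity of two naphthoquinone sulfonylamidines and a dichlorophenyl analogue

A few compounds are considered here, and "the series" means these few. Any claim that something is new, unique, unknown or untested is made for them only; others in the source may bear on it.

Measured compounds:
compound 1 `Cc1ccc(S(=O)(=O)/N=C(/CCNC2=CC(=O)c3ccccc3C2=O)Nc2ccc(Cl)cc2)cc1` 65400 nM
compound 2 `COc1ccc(N/C(CCNC2=CC(=O)c3ccccc3C2=O)=N\S(=O)(=O)c2ccc(C)cc2)c(OC)c1` 83000 nM

Compound 2 `COc1ccc(N/C(CCNC2=CC(=O)c3ccccc3C2=O)=N\S(=O)(=O)c2ccc(C)cc2)c(OC)c1` and compound 1 `Cc1ccc(S(=O)(=O)/N=C(/CCNC2=CC(=O)c3ccccc3C2=O)Nc2ccc(Cl)cc2)cc1` share the same core and differ only in the aryl group on the amine nitrogen. In an ADME assay on HEK293 cells (Homo sapiens) for cytotoxicity, read by MTT assay, with a stated time of 48 h (on this read-out higher numbers stand for weaker inhibition and lower numbers for stronger inhibition), compound 1 gives 65400 nM and compound 2 gives 83000 nM. Compound 2 holds the higher of the two numbers, but the step of a 1.3-fold higher number from compound 1 to compound 2 (0.10 log units; within the scatter) is within the scatter, so the two compounds cannot be told apart on this read-out.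

Compound 3 `Cc1ccc(S(=O)(=O)/N=C(/CCNC2=CC(=O)c3ccccc3C2=O)Nc2ccc(Cl)cc2Cl)cc1` has not been measured in this assay. It differs from compound 2 by 2,4-dichlorophenyl in place of 2,4-dimethoxyphenyl on an amine nitrogen. Among the measured compounds shown here, the only measured step that bears on this change is the one from compound 1 to compound 2, which also swapped the aryl group on the amine nitrogen and moved the number only a 1.3-fold higher number from compound 1 to compound 2 (0.10 log units; within the scatter). Since that exchange of aryl groups left the number within the scatter, a similar outcome is expected here, with no step beyond the scatter in either direction. Compound 3 is therefore expected to give about 70000 nM in this assay, with a range of 35000 nM to 140000 nM, an expected step of a 1.2-fold lower number from compound 2 to compound 3 (0.07 log units; within the scatter) from compound 2.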

Compound 3, half-maximal inhibitory concentration: 41900 nM
Compound 3: middle estimate off by 1.7-fold (0.22 log units), on the high side; measured number inside the range.
By their numbers in this assay, from the lowest: compounds 3, 1 and 2 (each within the scatter of the next).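

In this assay, 2,4-dichlorophenyl in place of 2,4-dimethoxyphenyl on the amine nitrogen gives a 2.0-fold lower number from compound 2 to compound 3 (0.30 log units; within the scatter) and so stays within the scatter, even though this exchange replaces both oxygen-bearing groups with chlorine atoms. The second comparison, chloro in place of hydrogen on an aromatic carbon, adds a single substituent to the aryl ring and gives a 1.6-fold lower number from compound 1 to compound 3 (0.19 log units; within the scatter) and this step also stays within the scatter, so this read-out separates none of the three aryl groups now seen at this position. No measurement shown here offers a reason for these numbers.

The three compounds leave open whether the same holds for groups of another kind on this nitrogen, such as a pyridine ring, a cyclohexyl group or a phenyl ring bearing a carboxylic acid. They also leave open whether a change elsewhere on the shared core, such as a longer chain to the amino group on the quinone side, would move the number beyond the scatter.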